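The source may hold more compounds than are shown below. What is called first, only, known or untested is meant among the compounds shown, and "the series" means these compounds.

Measured so far:
Compound 1 `C[C@H]1CC[C@@H]2[C@@H](OC(=O)[C@]23CC(c2c(Cl)cccc2Cl)=NO3)[C@]2(C)C(=O)C=C[C@@]12O` value 38000 nM
Compound 2 `COc1ccc(C2=NO[C@]3(C2)C(=O)O[C@@H]2[C@H]3CC[C@H](C)[C@]3(O)C=CC(=O)[C@@]23C)cc1` value 20000 nM

In a functional assay on DU-145 cells (Homo sapiens) for cytotoxicity, read by sulforhodamine B assay, with a stated time of 48 h (a lower number here means a stronger inhibitor, a higher number a weaker inhibitor), compound 2 gives 20000 nM and lies within the scatter of compound 1, so the two numbers cannot be ranked against each other.

Compound 3 `C[C@H]1CC[C@@H]2[C@@H](OC(=O)[C@]23CC(c2ccc(Cl)cc2)=NO3)[C@]2(C)C(=O)C=C[C@@]12O` keeps the core of compound 2 and changes one group. It has chloro in place of methoxy on an aromatic carbon, para to a large group, so 4-methoxyphenyl becomes 4-chlorophenyl (chloro in place of methoxy on an aromatic carbon).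

Among the measured compounds shown here, only one measured step bears on this change (a 1.9-fold lower number from compound 1 to compound 2 (0.28 log units; within the scatter)). For the measured compounds named here, it replaces 2,6-dichlorophenyl with 4-methoxyphenyl on a carbon with a double bond to nitrogen, so it touches the same group, but no measurement yet compares chloro with methoxy directly. Given that single small step (a 1.9-fold lower number from compound 1 to compound 2 (0.28 log units; within the scatter)), no step beyond the scatter is expected for compound 3 in this assay as the data stand. The estimated step is small (a 1.3-fold higher number from compound 2 to compound 3 (0.10 log units; within the scatter)). Compound 3 is expected at 25000 nM (estimated range 10000 nM to 60000 nM).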

Compound 3, half-maximal inhibitory concentration: 43000 nM
Beside the measured number, compound 3's estimate is 1.7-fold (0.24 log units) below it; the range from low to high includes it.
By their numbers in this assay, from the lowest: compounds 2, 1 and 3 (each within the scatter of the next, the first and the last beyond it).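

In this assay, putting chloro in place of methoxy on an aromatic carbon, para to a large group, gives a 2.2-fold higher number from compound 2 to compound 3 (0.33 log units; beyond the scatter) and so turns 4-methoxyphenyl into 4-chlorophenyl. This modest change is the only step among these compounds that lies beyond the usual scatter, and it is the first direct comparison of these two groups at this position. Going from 2,6-dichlorophenyl to 4-chlorophenyl gives a 1.1-fold higher number from compound 1 to compound 3 (0.05 log units; within the scatter) and lies within the scatter, so in this assay these two chlorine-bearing groups cannot be told apart, and the data offer no measured explanation for the difference between methoxy and chloro.

The compounds shown leave open whether an amine or a carboxylic acid on the same aromatic carbon would push the number lower or higher, and whether any such group could bring a larger step than the modest one seen here. They also leave open whether a longer chain, such as ethoxy in place of methoxy, would follow compound 2 or differ from it.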